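A few compounds are considered here, and "the series" means these few. Any claim that something is new, unique, unknown or untested is made for them only; others in the source may bear on it.

Working notes on the series. Compound 1 `CCCCCCCCCCCCCC[C@@H](O)[C@@H](O)[C@H](CO)n1cc(CCCC)nn1`, compound 2 `CCCCCCCCCCCCCC[C@@H](O)[C@@H](O)[C@H](CO)n1cc(CCCCCC)nn1` and compound 3 `CCCCCCCCCCCCC/C=C/[C@@H](O)[C@H](CO)n1cc(CCCCCC)nn1` have been measured; compound 4 `CCCCCCCCCCCCC/C=C/[C@@H](O)[C@H](CO)n1cc(CCCC)nn1` has not. In a functional assay on K562 cells (Homo sapiens) for cytotoxicity, read by MTT assay (a higher number here means that more compound is needed for the effect, a lower number that less compound is needed), compound 1 gives 14500 nM, compound 2 gives 12600 nM and compound 3 gives 8200 nM. Compound 2 and compound 1 differ by hydrogen in place of ethyl on a saturated chain carbon, four bonds along the chain from an aromatic carbon, a change that gave a 1.2-fold higher number from compound 2 to compound 1 (0.06 log units; within the scatter). The difference between the core of compound 2 and the core of compound 3 is not broken down here. Compound 3 and compound 4 differ by hydrogen in place of ethyl on a saturated chain carbon, four bonds along the chain from an aromatic carbon, the same change at the same place, seen once already between the measured pair. Because that change gave a 1.2-fold higher number from compound 2 to compound 1 (0.06 log units; within the scatter), a step of a 1.2-fold higher number from compound 3 to compound 4 (0.06 log units; within the scatter) is expected in this assay. Compound 4 is accordingly estimated at 9500 nM, with a likely range from 5000 nM to 18000 nM, pending the measurement.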

Compound 4, half-maximal effective concentration: 12300 nM
For compound 4 the middle estimate is 1.3-fold (0.11 log units) below the measured one; measured number inside the range.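

In this assay, hydrogen in place of ethyl gives a 1.5-fold higher number from compound 3 to compound 4 (0.18 log units; within the scatter), and the two cores do not separate on this change: the same change on two cores in this assay, a 1.2-fold higher number (0.06 log units; within the scatter) from compound 2 to compound 1 and a 1.5-fold higher number (0.18 log units; within the scatter) from compound 3 to compound 4, 1.3-fold (0.12 log units) apart, within the scatter of two such steps. Among the compounds shown here, both steps lie within the scatter, so the pair shows only that the change leaves the number unresolved on either core, not that a step of a particular size carries over. Two cores are a narrow base, and agreement between two such small steps says nothing about other cores in the series.

Still open, on these data alone, is whether a longer chain on the aromatic ring would move the number beyond the scatter. Also open, as far as these compounds go, is whether an amine or a carboxylic acid at the end of that chain would do so.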